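Trimethoxyphenyl thiadiazine series: carbonyl aryl variation and cytotoxicity

The compounds below may be only part of what the source reports. "The series", "measured", "known", "first", "only" and "open" are said of these compounds alone.

Measured compounds in a functional assay on HepG2 cells (Homo sapiens) for cytotoxicity, read by MTT assay, with a stated time of 48 h; a higher number here means a weaker inhibitor, a lower number a stronger inhibitor:
- compound 1 `COc1cc(-c2nnc3n2NC(c2ccco2)C(C(=O)c2ccc(F)c(F)c2)S3)cc(OC)c1OC`: 52400 nM
- compound 2 `COc1ccc(C(=O)C2Sc3nnc(-c4cc(OC)c(OC)c(OC)c4)n3NC2c2ccco2)cc1`: > 100000 nM, a limit of the assay and not a number
- compound 3 `COc1cc(-c2nnc3n2NC(c2ccco2)C(C(=O)c2ccc(Br)cc2)S3)cc(OC)c1OC`: > 100000 nM, likewise a limit of the assay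

Compound 2 stands at the limit of this assay, and no number is known for it. For the measured compounds named here, compound 1 is the only member with a number. The step of an at least 1.9-fold higher number from compound 1 to compound 2 (0.28 log units; that floor lies within the scatter) and the step of an at least 1.9-fold higher number from compound 1 to compound 3 (0.28 log units; that floor lies within the scatter) are both read only against the limit, and the step that the two limits leave unreadable from compound 2 to compound 3 cannot be read at all, since both ends sit at the limit (the limit of > 100000 nM in this assay, at which 2 of the 3 values shown sit).

Compound 4 `COc1cc(-c2nnc3n2NC(c2ccco2)C(C(=O)c2ccc(Cl)cc2)S3)cc(OC)c1OC` differs from compound 2 as follows: chloro in place of methoxy on an aromatic carbon. The nearest measured neighbour for this change is compound 3, which carries bromo at the same place and sits at the limit. With compound 2 and compound 3 both at the limit, the step from compound 2 to compound 4 in this assay is expected to be small or unreadable, most likely a value again at or near the limit; the estimate for compound 4 is 100000 nM, from 40000 nM to 300000 nM, meaning an expected step of a number no higher from compound 2 to compound 4 (the limit leaves the size open).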

Compound 4, half-maximal inhibitory concentration: 78600 nM
Beside the measured number, compound 4's estimate is 1.3-fold (0.10 log units) above it, and the stated range covers the measured number.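

Compound 4 gives the series a second true number in this assay, so the place para to a large group on the aryl ring of the carbonyl now holds one group that reads below the limit. Chloro in place of methoxy reads as an at least 1.2-fold lower number from compound 2 to compound 4 (0.10 log units; that floor lies within the scatter), and chloro in place of bromo reads as an at least 1.2-fold lower number from compound 3 to compound 4 (0.10 log units; that floor lies within the scatter); both are floors set against limits, so neither change can yet be sized, and chloro cannot be ranked against methoxy or bromo. Against the 3,4-difluorophenyl group, the 4-chlorophenyl group reads as a 1.5-fold higher number from compound 1 to compound 4 (0.18 log units; within the scatter), so the only two members with numbers are not separated, and the remaining comparisons stay bounded by the limit: the limit of > 100000 nM in this assay, at which 2 of the 4 values shown sit.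

The compounds shown leave open whether the true values of compound 2 and compound 3 lie close to that of compound 4 or far from it. They also leave open how an amine or a carboxylic acid at this same place would read, and whether any group there gives a step beyond the scatter.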